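Swapping fluoro for chloro on a shared sulfonyl quinoxaline core

This account rests on a few compounds, and the source may have more. Where it says the series, first, only, none or still open, it means among the compounds named here.

Three compounds share one core and were tested in a functional assay on A549 cells (Homo sapiens) for cytotoxicity, read by MTT assay, with a stated time of 72 h; on this read-out lower numbers stand for stronger inhibition and higher numbers for weaker inhibition. Compound 1 `COc1ccc(S(=O)(=O)c2nc3ccccc3nc2Nc2ccc(F)cc2)cc1` gives 1240 nM. Compound 2 `COc1ccc(S(=O)(=O)c2nc3ccccc3nc2Nc2ccc(Cl)cc2)cc1` gives 87300 nM, and compound 3 `O=S(=O)(c1ccc(Br)cc1)c1nc2ccccc2nc1Nc1ccc(F)cc1` gives 4360 nM. The change from compound 1 to compound 2, (chloro in place of fluoro on an aromatic carbon), made a large step, a 70-fold higher number from compound 1 to compound 2 (1.85 log units; beyond the scatter). The cores of compound 1 and compound 3 differ by bromo in place of methoxy on an aromatic carbon, which made a modest step, a 3.5-fold higher number from compound 1 to compound 3 (0.55 log units; beyond the scatter). Compound 4 `O=S(=O)(c1ccc(Br)cc1)c1nc2ccccc2nc1Nc1ccc(Cl)cc1` is not yet measured; it differs from compound 3 by chloro in place of fluoro on an aromatic carbon, the same change that took compound 1 to compound 2. Among the measured compounds shown here, because a 70-fold higher number from compound 1 to compound 2 (1.85 log units; beyond the scatter) was large, a large step is expected in this assay too, a 21-fold higher number from compound 3 to compound 4 (1.31 log units; beyond the scatter), though only one earlier example supports this. Compound 4 is therefore estimated at 90000 nM, within 15000 nM to 400000 nM.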

Compound 4, half-maximal inhibitory concentration: 61400 nM
Compound 4: middle estimate off by 1.5-fold (0.17 log units), on the high side; measured number inside the range.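

In this assay, chloro in place of fluoro again gives a large rise on the core carrying bromo, a 14-fold higher number from compound 3 to compound 4 (1.15 log units; beyond the scatter), so the direction of this change carries from one core to the other, but its size does not: the same change on two cores in this assay, a 70-fold higher number (1.85 log units; beyond the scatter) from compound 1 to compound 2 and a 14-fold higher number (1.15 log units; beyond the scatter) from compound 3 to compound 4, 5.0-fold (0.70 log units) apart, beyond the scatter of two such steps Bromo in place of methoxy carries less well, since with chloro on the other ring the step is a 1.4-fold lower number from compound 2 to compound 4 (0.15 log units; within the scatter), which lies within the scatter: the same change on two cores in this assay, a 3.5-fold higher number (0.55 log units; beyond the scatter) from compound 1 to compound 3 and a 1.4-fold lower number (0.15 log units; within the scatter) from compound 2 to compound 4, 5.0-fold (0.70 log units) apart, beyond the scatter of two such steps The two changes therefore do not act independently in these four compounds, though four compounds cannot show why, or how general this is.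

From the compounds shown here alone, whether a methyl group or an amine in place of the fluoro would behave like chloro remains open. So does whether these steps would hold in other cell lines.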